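Halogen swap on the aryl ring and cytotoxicity

The compounds below may be only part of what the source reports. "The series", "measured", "known", "first", "only" and "open" are said of these compounds alone.

In an ADME assay on HepG2 cells (Homo sapiens) for cytotoxicity, read by MTT assay, with a stated time of 72 h (on this read-out lower numbers stand for higher toxicity in this test and higher numbers for lower toxicity in this test), compound 1 `CC(C)Nc1nc2cc(-c3ccc(Br)cc3)sc2c(=O)[nH]1` gives 13400 nM. Compound 2 `CC(C)Nc1nc2cc(-c3ccc(F)cc3)sc2c(=O)[nH]1` reaches only a limit of the assay, > 25000 nM. Compound 3 `CC(C)Nc1nc2c(-c3ccc(F)cc3)csc2c(=O)[nH]1` also reaches only a limit of the assay, > 15600 nM. The difference between the cores of compound 2 and compound 3 is not broken down here. The change bromo in place of fluoro on an aromatic carbon made an at least 1.8-fold lower number from compound 2 to compound 1 (0.27 log units; that floor lies within the scatter), a step that rests on a limit, (the limit of > 25000 nM in this assay, at which 1 of the 3 values shown sits). The same change, at a place described in the same words, is bromo in place of fluoro on an aromatic carbon, leading to compound 4 `CC(C)Nc1nc2c(-c3ccc(Br)cc3)csc2c(=O)[nH]1`. Compound 4 is expected to show a step of about an at least 1.3-fold lower number from compound 3 to compound 4 (0.11 log units; that floor lies within the scatter) in this assay, resting on an at least 1.8-fold lower number from compound 2 to compound 1 (0.27 log units; that floor lies within the scatter). The estimate for compound 4 is 12000 nM, expected to lie between 5000 nM and 30000 nM.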

Compound 4, half-maximal cytotoxic concentration: 6500 nM
The estimate for compound 4 lay 1.8-fold (0.27 log units) above the measured number, within the range that was stated.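

In this assay, bromo in place of fluoro gives an at least 2.4-fold lower number from compound 3 to compound 4 (0.38 log units; beyond the scatter), so on the core of compound 4 the change moves toward higher toxicity in this test, and the number falls in the same direction as on the core of compound 1. Compound 3 stands only at a limit of the assay, > 15600 nM, so this step is a floor and not a measured size. Carrying the change across these two cores is therefore shown in direction only, not in size: the same change on two cores in this assay, an at least 1.8-fold lower number (0.27 log units; that floor lies within the scatter) from compound 2 to compound 1 and an at least 2.4-fold lower number (0.38 log units; beyond the scatter) from compound 3 to compound 4; the limit leaves it open whether they differ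

The compounds shown leave open how a 4-chlorophenyl, 4-methoxyphenyl or 4-aminophenyl group would read on either core. They also leave open whether the step holds on any core beyond these two.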